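The compounds below may be only part of what the source reports. "The series", "measured", "known", "first", "only" and "open" are said of these compounds alone.

Working notes on the series. Compound 2 `NCC[C@@H]1CCO[C@H](c2ccccc2)O1` was examined in an assay on brain for displacement of a labelled ligand from Sigma non-opioid intracellular receptor 1 (Cavia porcellus); a lower number here means a stronger inhibitor, a higher number a weaker inhibitor. Compound 2 returns only a limit of the assay there, > 10000 nM. Compound 1 `CCC[C@]1(c2ccccc2)OCC[C@H](CCN)O1` likewise gives no number in this assay but the limit > 10000 nM. Among the compounds with values here, both measured compounds thus sit at the same ceiling (the limit of > 10000 nM in this assay, at which 2 of the 2 values shown sit), so no step between measured compounds can be drawn, and how far beyond that ceiling either lies is unknown. Compound 3 `CCC[C@@]1(c2ccccc2)OCC[C@@H](CCN)O1` has not yet been measured in this assay. It differs from compound 2 by propyl in place of hydrogen on a saturated ring carbon. With both measured values at the limit, the numbers support neither a direction nor a size for this change. The change is expected to produce a step that the limit leaves unreadable from compound 2 to compound 3, which cannot be told apart from none beyond the scatter. Compound 3 is estimated at 15000 nM in this assay, with a range from 3000 nM to 60000 nM, and a further limit rather than a number is the more likely outcome.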

Compound 3, inhibition constant: > 10000 nM
Compound 3: only a limit was reported; the forecaster's own chance of this, stated with the estimate: 75%; the middle value does not contradict the limit.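

Compound 3 gives only a limit, > 10000 nM, so no step from compound 1 or compound 2 to it can be read: the limit of > 10000 nM in this assay, at which 3 of the 3 values shown sit.

The compounds shown leave open how far beyond that limit each lies, and so whether propyl in place of hydrogen or the inverted configuration changes anything in this assay.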